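This account rests on a few compounds, and the source may have more. Where it says the series, first, only, none or still open, it means among the compounds named here.

Three compounds have been run through a functional assay on NCI-H520 cells (Homo sapiens) for inhibition, read by MTT assay, with a stated time of 48 h, tested at 10 uM (a lower number here means less inhibition, a higher number more inhibition at the concentration tested (going by the name of the read-out)), all at the same single concentration. Compound 1, `COc1cc(NC(=O)Nc2cc(Nc3ccc(OC)c(C)c3)ncn2)cc(OC)c1`, gives 13.5% in this assay. Compound 2, `Cc1ccc(Nc2cc(NC(=O)Nc3c(Cl)cccc3Cl)ncn2)cc1F`, gives 33.5%, and compound 3, `COc1cc(Nc2cc(NC(=O)Nc3c(Cl)cccc3Cl)ncn2)cc(C(F)(F)F)c1`, gives 23.1%. Among these three numbers compound 1 stands lowest. Its gap to compound 3 is within the scatter of repeated measurements, so the two cannot be told apart; its gap to compound 2 is beyond that scatter, so compound 2 does inhibit more at this concentration.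

Compound 4, `COc1cc(NC(=O)Nc2cc(Nc3ccc(OC)c(I)c3)ncn2)cc(OC)c1`, has not yet been measured. It differs from compound 1 in one place: iodo in place of methyl on an aromatic carbon. For the measured compounds named here, no measured pair shows this exchange, so its effect here is not known from the data. Both groups are single heavy atoms without donors, acceptors or charge, and on this basis the expectation is a step of no more than the scatter, leaning neither strongly up nor down, as a number 4.5 percentage points higher from compound 1 to compound 4 (within the scatter). The estimate for compound 4 in this assay is accordingly 18%, with a range running from 5% to 35%.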

Compound 4, a percentage reported as inhibition, at one concentration (the size of the read-out at that concentration, not a potency): 46.5%
The estimate for compound 4 lay 28.5 percentage points below the measured number, and the stated range ends below it.
By their numbers in this assay, from the lowest: compounds 1 and 3 (each within the scatter of the next); then compound 2; then compound 4.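

In this assay, exchanging the methyl of the 4-methoxy-3-methylphenyl group for iodo, on an aromatic carbon ortho to a methoxy group, gives a number 33 percentage points higher from compound 1 to compound 4 (beyond the scatter). For the compounds shown here, this is the first single-place comparison, and it shows that this position is not indifferent: methyl and iodo each count as one heavy atom with no hydrogen-bond donors, acceptors or charge, yet the two compounds clearly differ, so those counts alone do not tell these groups apart here. No measurement shown identifies which feature of the iodo group lies behind the step.

The compounds shown leave open whether the response at this position follows a trend, as a single pair cannot show how chloro, bromo or an amine on the same carbon would compare with methyl and iodo. They also leave open whether the same exchange would produce a step of similar size with the other parts of the molecule changed, and, as every number comes from one concentration, how the compounds compare in potency.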